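The source may hold more compounds than are shown below. What is called first, only, known or untested is meant among the compounds shown, and "the series" means these compounds.

Measured so far:
compound 1 `Cc1c(C=O)cc(-c2ccc(S(C)(=O)=O)cc2)n1-c1ccccc1` — 30%
compound 2 `Cc1c(/C=N\O)cc(-c2ccc(S(C)(=O)=O)cc2)n1-c1ccc(F)c(F)c1` — "not determined" (no result reported)

Notes on the series. The read-out is a functional assay on the whole organism (strain Swiss albino) for inhibition, with Mus musculus as the target, in the writhing test, with a stated time of 30 min, at a dose of 40 mg/kg by the oral route; on this read-out lower numbers stand for a weaker effect and higher numbers for a stronger effect at the one dose given. Within the data shown here, only one number exists in it: compound 1 gives 30%. Among the measured compounds shown here, for compound 2 the read-out is "not determined" (no result reported), so compound 2 stands nowhere on the scale; no comparison with compound 1 can be drawn from it, and no step between measured compounds is available.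

The next compound, compound 3 `Cc1c(/C=N\O)cc(-c2ccc(S(C)(=O)=O)cc2)n1-c1ccccc1`, is to be measured in this assay. It differs from compound 2 in one place: phenyl in place of 3,4-difluorophenyl on an aromatic nitrogen. Since compound 2 carries no number, the size of this step in this assay cannot be anchored to a measured pair; from the nature of the change, a shift of moderate size in either direction, or none beyond the scatter, is all that can be expected, with no basis to favour a direction.

Against the single number in the series, compound 1 at 30%, compound 3 is estimated at 35%, with an expected range from 15% to 60%.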

Compound 3, a percentage reported as inhibition, in the whole organism at one dose (the size of the read-out at that dose, not a potency): 57%
The estimate for compound 3 lay 22 percentage points below the measured number, and the stated range covers the measured number.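

In this assay, with the phenyl on the aromatic nitrogen held constant, exchanging the aldehyde on the aromatic carbon for the oxime gives a number 27 percentage points higher from compound 1 to compound 3 (beyond the scatter). Among these compounds, this is the first readable step, and it shows that the read-out responds to a change at this aromatic carbon, at least in the setting of the phenyl compounds. Compound 2 carries no number, so the step between 3,4-difluorophenyl and phenyl on the aromatic nitrogen cannot be read, and nothing available accounts for the rise seen with the oxime.

The compounds shown leave open whether the gain is particular to the oxime or would also appear with other groups on that aromatic carbon, such as a nitrile, a carboxylic acid, an amide or an O-methyl oxime. They also leave open how the oxime behaves with anything other than phenyl on the aromatic nitrogen, such as 4-fluorophenyl or 4-methoxyphenyl, and whether the step between compound 1 and compound 3 holds at other oral doses.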